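This account rests on a few compounds, and the source may have more. Where it says the series, first, only, none or still open, it means among the compounds named here.

Measured compounds in the series:
- compound 2 `CO[C@]1(C)C[C@H](O)C[C@@H](CSc2nc(-c3ccccc3)c(-c3ccccc3)[nH]2)O1` — 30 nM
- compound 3 `CO[C@H]1C[C@H](O)C[C@@H](CSc2nc(-c3ccccc3)c(-c3ccccc3)[nH]2)O1` — 90 nM
- compound 1 `CC1=CC(=O)OC(CSc2nc(-c3ccccc3Cl)c(-c3ccccc3Cl)[nH]2)C1` — 1700 nM

Working notes. In an assay on microsomes from liver for inhibition of sterol O-acyltransferase 1 (Rattus norvegicus) (on this read-out higher numbers stand for weaker inhibition and lower numbers for stronger inhibition), compound 3 gives 90 nM, the second highest of the three numbers. Among the compounds with values here, its nearest neighbour is compound 2, which in this assay gives 30 nM; the step of a 3.0-fold higher number from compound 2 to compound 3 (0.48 log units; beyond the scatter) is the only single-point change recorded so far. Compound 1, with chlorophenyl groups and a different ring on the chain, gives 1700 nM in this assay, the furthest of the set from compound 3.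

Compound 4 `c1ccc(-c2nc(SCCC3OCCCO3)[nH]c2-c2ccccc2)cc1` is not yet measured. It differs from compound 3 by a group of 7 heavy atoms (5 carbon, 2 oxygen; one six-membered non-aromatic ring with 2 hetero atoms) in place of a group of 9 heavy atoms (6 carbon, 3 oxygen; one six-membered non-aromatic ring with 1 hetero atom), on a saturated chain carbon bound to a sulfur, so the hydroxyl-bearing ring with its defined stereocentres gives way to a smaller ring carrying no hydrogen-bond donor. Within the data shown here, no measured step covers this exchange directly; the step from compound 2 to compound 3 shows only that removing a single methyl from the saturated ring already costs a modest amount in this assay, and compound 1 shows that a different ring on the chain sits far weaker, though its chlorophenyl groups also differ.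

On that basis the expectation for compound 4 is a weakening beyond the scatter, of the order a 3.9-fold higher number from compound 3 to compound 4 (0.59 log units; beyond the scatter), estimated at 350 nM with a range of 90 nM to 1400 nM.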

Compound 4, half-maximal inhibitory concentration: 730 nM
Beside the measured number, compound 4's estimate is 2.1-fold (0.32 log units) below it, within the range that was stated.
By their numbers in this assay, from the lowest: compound 2; then compound 3; then compound 4; then compound 1.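

In this assay the exchange on the saturated chain carbon bound to a sulfur gives an 8.1-fold higher number from compound 3 to compound 4 (0.91 log units; beyond the scatter) and the shared core stays unchanged, so this position alone accounts for the change; compound 1 could not show this, as its chlorophenyl groups also differ. Compound 4 still gives a finite value of 730 nM with 0 hydrogen-bond donors and no defined stereocentres in the entering group, so neither feature is required for a measurable number in this assay. The exchange alters the heavy atom count, the ring hetero atoms, the hydrogen-bond donor and the stereocentres together, so the step cannot be divided among them, and no supporting data explain its size.

The compounds shown do not separate these changes: a hydroxyl or an amine on the ring of compound 4 would test the donor apart from the ring, and a single stereoisomer pair would test the stereocentres. Also open, as far as these compounds go, is how a longer chain between the sulfur and either ring would read, since both compound 3 and compound 4 leave the effect of chain length untested.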